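The source may hold more compounds than are shown below. What is called first, only, known or untested is meant among the compounds shown, and "the series" means these compounds.

Compound 1 `COc1nc(-c2ccc3nc(NC(C)=O)cn3c2)cnc1N`, 23000 nM; compound 2 `COc1cc(-c2ccc3nc(NC(C)=O)cn3c2)cnc1N`, 160000 nM; compound 3 `CCOc1cc(-c2ccc3nc(NC(C)=O)cn3n2)cnc1N`, 13000 nM.

Of the compounds shown here, three have been measured in a physicochemical assay for solubility, in phosphate buffer, at pH 7.4; a higher number here means a more soluble compound, a lower number a less soluble compound. Compound 1 stands second highest of the three: compound 3 gives a slightly lower number that lies within the scatter of it, while compound 2 gives a higher number that lies beyond the scatter. Compound 4 `COCCOc1nc(-c2ccc3nc(NC(C)=O)cn3c2)cnc1N` has not been measured. It differs from compound 1 in one place: methoxymethyl in place of hydrogen on a saturated chain carbon bound to an oxygen on an aromatic ring. Among the measured compounds shown here, no two measured compounds differ in a single place, so the size of such a step is not known from these data. The expectation is a small step upward in this assay, not clearly beyond the scatter. Compound 4 is therefore estimated at 30000 nM, with a range from 10000 nM to 90000 nM. The step of a 1.3-fold higher number from compound 1 to compound 4 (0.12 log units; within the scatter) is the one expected.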

Compound 4, solubility: 25000 nM
Compound 4: middle estimate off by 1.2-fold (0.08 log units), on the high side, and the stated range covers the measured number.
By their numbers in this assay, from the lowest: compounds 3, 1 and 4 (each within the scatter of the next); then compound 2.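

Among the compounds shown here, compound 4 gives the first single-place comparison in this assay and it reads a 1.1-fold higher number from compound 1 to compound 4 (0.04 log units; within the scatter) so, at this position, going from methoxy to 2-methoxyethoxy leaves the read-out within the scatter. The position thus carries the longer chain and its added oxygen without a step beyond the scatter. Nothing measured here explains this result.

On these data alone, whether an amine, a carboxylic acid or a still longer chain at this position would give a step beyond the scatter remains open. So does whether methoxy to 2-methoxyethoxy would read the same on the core of compound 2.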